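This account rests on a few compounds, and the source may have more. Where it says the series, first, only, none or still open, it means among the compounds named here.

Compound 1, `N#CCN(Cc1ccc(Br)cc1)Cc1ccc2ccccc2c1`, belongs to a small set of three measured compounds sharing one core. In an assay on HEK293 cells for binding affinity to Substance-K receptor (Rattus norvegicus), read by FRET, tested at 10 uM (on this read-out lower numbers stand for less inhibition and higher numbers for more inhibition at the one concentration tested (going by the name of the read-out)), compound 1 gives 0%, level with compound 2 at the digits shown and together with it the lowest of the three numbers. Compound 2, `N#CCN(Cc1ccc(I)cc1)Cc1ccc2ccccc2c1`, gives 0% in this assay, and the step of no change at the digits printed from compound 1 to compound 2 (within the scatter) is within the scatter. Compound 3, `N#CCN(Cc1ccc(CCc2ccccc2)cc1)Cc1ccc2ccccc2c1`, gives 20% in this assay, so that a number 20 percentage points higher from compound 1 to compound 3 (beyond the scatter) and likewise a number 20 percentage points higher from compound 2 to compound 3 (beyond the scatter).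

Compound 4 is `COc1ccc(CN(CC#N)Cc2ccc3ccccc3c2)cc1`. It differs from compound 1 by methoxy in place of bromo on an aromatic carbon. Going by the values given here, no measured step swaps the bromo for a small oxygen-bearing group, so the evidence bears only indirectly. The step from bromo to iodo in no change at the digits printed from compound 1 to compound 2 (within the scatter) left the number unchanged, while the step to phenethyl in a number 20 percentage points higher from compound 1 to compound 3 (beyond the scatter) raised it modestly. Methoxy enters with two heavy atoms, far closer in size to the halogens than to phenethyl, so compound 4 is expected to behave like compounds 1 and 2 rather than like compound 3, giving a step of a number 5 percentage points higher from compound 1 to compound 4 (within the scatter) that stays within the scatter. The estimate for compound 4 in this assay is therefore 5%, with a range from 0% to 20%.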

Compound 4, a percentage reported as inhibition, at one concentration (the size of the read-out at that concentration, not a potency): 0%
For compound 4 the middle estimate is 5 percentage points above the measured one; measured number inside the range.
By their numbers in this assay, from the lowest: compounds 1, 2 and 4 (each within the scatter of the next); then compound 3.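

In this assay, methoxy brings in an oxygen and a hydrogen-bond acceptor that neither halogen has, yet this replacement gives no change at the digits printed from compound 1 to compound 4 (within the scatter) and no change at the digits printed from compound 2 to compound 4 (within the scatter), so on this aromatic carbon the read-out does not separate methoxy from bromo or iodo. Among the four compounds, only phenethyl stands apart from the other three groups, as a number 20 percentage points lower from compound 3 to compound 4 (beyond the scatter) shows when it gives way to methoxy. Nothing available here accounts for why phenethyl alone stands apart.

As far as these compounds go, what a butyl chain or a benzyloxy group would give at this position remains open, and with it whether the higher number of compound 3 calls for the terminal phenyl ring or only for a longer substituent. From the compounds shown here alone, it is equally open whether an amine or a carboxylic acid here would move the number at all, and, with a single tested concentration, how compounds reading alike would compare in potency.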